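Swapping the para substituent on a benzylamine tail

This account rests on a few compounds, and the source may have more. Where it says the series, first, only, none or still open, it means among the compounds named here.

Two close analogues share one core and differ only in the group on the outer benzene ring. Compound 1 `Cc1cc(Nc2nc(NCc3ccc(Br)cc3)nc3ccccc23)n[nH]1` carries a bromo there, and in an assay for inhibition of high affinity nerve growth factor receptor (Homo sapiens), read by HTRF, with a stated time of 30 min, in the presence of a further agent that is not named here (a lower number here means a stronger inhibitor, a higher number a weaker inhibitor), compound 1 gives 180 nM. Compound 2 `Cc1ccc(CNc2nc(Nc3cc(C)[nH]n3)c3ccccc3n2)cc1` carries a methyl in its place, and in this assay compound 2 gives 110 nM. Going by the values given here, the only measured step, a 1.6-fold lower number from compound 1 to compound 2 (0.21 log units; within the scatter), is within the scatter, so compound 2 and compound 1 stand at numbers that cannot be told apart, and neither can be called the stronger inhibitor.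

Compound 3 `Cc1cc(Nc2nc(NCc3ccc(OC(F)(F)F)cc3)nc3ccccc23)n[nH]1` is the next member of the series. Its change from compound 2 is trifluoromethoxy in place of methyl on an aromatic carbon. Among the compounds with values here, the one step that bears on this change is the earlier swap at the same position, which moved the number by a 1.6-fold lower number from compound 1 to compound 2 (0.21 log units; within the scatter) and stayed within the scatter. On that basis the expected step in this assay is a 1.2-fold higher number from compound 2 to compound 3 (0.07 log units; within the scatter), that is, no change beyond the scatter in either direction. Compound 3 is therefore estimated at 130 nM, with a range from 50 nM to 350 nM.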

Compound 3, half-maximal inhibitory concentration: 4100 nM
Estimate against measurement, compound 3: 32-fold (1.50 log units) below; the whole stated range lies below it.
By their numbers in this assay, from the lowest: compounds 2 and 1 (each within the scatter of the next); then compound 3.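

In this assay trifluoromethoxy in place of methyl gives a 37-fold higher number from compound 2 to compound 3 (1.57 log units; beyond the scatter) and trifluoromethoxy in place of bromo gives a 23-fold higher number from compound 1 to compound 3 (1.36 log units; beyond the scatter) and so both steps are large and beyond the scatter, with compound 3 the weakest inhibitor of the three. The earlier swap of bromo for methyl stayed within the scatter and could have suggested that this position accepts any small change, but these steps show that the group on this aromatic carbon can decide a great deal. Trifluoromethoxy brings 5 heavy atoms where methyl has 1, and it counts 1 hydrogen-bond acceptor where methyl has none, yet nothing available here ties the loss to either difference.

The compounds shown leave open whether the oxygen or the three fluorines go with the loss, a question that methoxy or trifluoromethyl on the same aromatic carbon could help to answer. They also leave open how this position would respond to quite different groups, such as an amine, a carboxylic acid or a longer alkyl chain.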